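A few compounds are considered here, and "the series" means these few. Any claim that something is new, unique, unknown or untested is made for them only; others in the source may bear on it.

Measured compounds:
- compound 1, `O=C(O)CCC/C=C1/C[C@H]2C[C@@H](O)[C@H](/C=N/NC(=O)Nc3ccc([N+](=O)[O-])cc3)[C@H]2C1`: 50 nM
- compound 2, `O=C(O)CC/C=C1/C[C@H]2C[C@@H](O)[C@H](/C=N/NC(=O)Nc3cccc(Cl)c3)[C@H]2C1`: 600 nM

In a functional assay on a cell-free system (plasma) for agonist activity at thromboxane A2 receptor (Homo sapiens) (a higher number here means a weaker inhibitor, a lower number a stronger inhibitor), compound 2 gives 600 nM, the higher of the two numbers recorded. In this assay compound 1 gives 50 nM, a number far below that of compound 2 and well beyond the scatter of the method; the two compounds differ in more than one place, however, so no single step can be read from that pair.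

Compound 3, `O=C(O)CC/C=C1/C[C@H]2C[C@@H](O)[C@H](/C=N/NC(=O)Nc3ccc([N+](=O)[O-])cc3)[C@H]2C1`, keeps the shorter acid chain of compound 2 and carries the change (4-nitrophenyl in place of 3-chlorophenyl on an amide-type nitrogen). For the measured compounds named here, no measured pair isolates this change, so the expected step rests only on the showing of the two measured compounds. Compound 3 is expected to give a lower number than compound 2 in this assay, because compound 1 gives 50 nM with the same 4-nitrophenyl group on the amide-type nitrogen. The expected step of a 4.0-fold lower number from compound 2 to compound 3 (0.60 log units; beyond the scatter) is moderate and downward. For compound 3 the estimated value in this assay is 150 nM, with a range from 40 nM to 600 nM.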

Compound 3, half-maximal inhibitory concentration: 20 nM
Estimate against measurement, compound 3: 7.5-fold (0.88 log units) above, and the stated range ends above it.
By their numbers in this assay, from the lowest: compound 3; then compound 1; then compound 2.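

In this assay, 4-nitrophenyl in place of 3-chlorophenyl on an amide-type nitrogen, now seen as a single change on the shorter acid chain, gives a 30-fold lower number from compound 2 to compound 3 (1.48 log units; beyond the scatter), so the group at this position accounts for a large share of the gap between compound 1 and compound 2. The other single change, carboxy in place of carboxymethyl on a saturated chain carbon, two bonds along the chain from a double-bonded chain carbon, gives a 2.5-fold lower number from compound 1 to compound 3 (0.40 log units; beyond the scatter), showing that with 4-nitrophenyl in place the shorter acid chain carries no penalty in this assay and that this step is much the smaller of the two. No measured evidence is available to explain either step.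

The compounds shown leave open whether the drop follows the nitro group or its place on the ring, a question that 3-nitrophenyl or 4-chlorophenyl on the same nitrogen would settle. Also open, as far as these compounds go, are whether the shorter chain gives a similar step with 3-chlorophenyl on that nitrogen and how a longer chain or a tetrazole in place of the carboxylic acid would read.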